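A Fluorinated Cyclopropyl Swap on the Shared Core

A few compounds are considered here, and "the series" means these few. Any claim that something is new, unique, unknown or untested is made for them only; others in the source may bear on it.

compound 1, `Cc1cc(NC(=O)Cn2nnc(-c3ccccc3)n2)n(C2CCC(C)(C)CC2)n1`: in an assay on HEK293 cells for activation of Kir3.1/Kir3.2 (Homo sapiens), read by thallium flux (a lower number here means a smaller maximal response, a higher number a larger maximal response), compound 1 gives > 19%, which is a limit of the assay rather than a number
compound 2, `CC1CC1c1cc(NC(=O)Cn2nnc(-c3ccccc3)n2)n(C2CCCCC2)n1`: compound 2 gives 78%

Among the two measured compounds, compound 2 is the only one with an actual number in this assay; the other entry is the limit of > 19% in this assay, at which 1 of the 2 values shown sits. Compound 3, `O=C(Cn1nnc(-c2ccccc2)n1)Nc1cc(C2(C(F)(F)F)CC2)nn1C1CCCCC1`, differs from compound 2 in one place: 1-(trifluoromethyl)cyclopropyl in place of 2-methylcyclopropyl on an aromatic carbon. Within the data shown here, no step between measured compounds is available for this kind of change, so its size cannot be read off a neighbouring pair, and the two values of compound 1 and compound 2 cannot be compared as a step at all. Compound 3 is therefore expected to remain in the same broad region as compound 2, with the uncertainty widened on both sides. The step of a number 13 percentage points lower from compound 2 to compound 3 (beyond the scatter) is expected to be a modest downward one, not far beyond the usual scatter. The estimate for compound 3 in this assay is 65%, with a range from 35% to 95%.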

Compound 3, largest response reached (Emax), in percent of the reference or control that the assay uses: "not active" (no number reported)
For compound 3 the study gives words and no number; the estimate stays without a comparison.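

Among these compounds, for compound 3, this assay gives only the words "not active" (no number reported), so no step from compound 2 can be read. The compounds shown leave open how far apart compound 2 and compound 3 lie, and compound 1 offers no number to help, only a limit: the limit of > 19% in this assay, at which 1 of the 3 values shown sits.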